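Piperidinyl amide variant of the dimethoxy tetralin acetamide series

The source may report more compounds than this note shows. Statements on the series, on what has been measured and on what is new or still open speak of the compounds shown alone.

Measured compounds:
compound 1 `CNC(=O)CC1CCc2cc(OC)c(OC)cc21` — 29.7%
compound 2 `COc1cc2c(cc1OC)C(CC(=O)NC(C)C)CC2` — 39.1%
compound 3 `CCCCNC(=O)CC1CCc2cc(OC)c(OC)cc21` — 25%

In a functional assay on the whole organism (strain Wistar) for inhibition, with Rattus norvegicus as the target, read by paw edema, with stated times of 60 min and 4 h, at a dose of 100 mg/kg by the oral route (a lower number here means less inhibition, a higher number more inhibition at the dose given (going by the name of the read-out)), compound 1 gives 29.7%, a number that sits between the other two, with both neighbours within the scatter: a number 9.4 percentage points higher from compound 1 to compound 2 (within the scatter) and a number 4.7 percentage points lower from compound 1 to compound 3 (within the scatter). For the measured compounds named here, the one step beyond the scatter is a number 14.1 percentage points lower from compound 2 to compound 3 (beyond the scatter), a modest one. Compound 4 `COc1cc2c(cc1OC)C(CC(=O)N1CCCCC1)CC2` differs from compound 1 by piperidin-1-yl in place of methylamino on a carbonyl carbon. Going by the values given here, no measured step removes the amide hydrogen or closes the nitrogen into a ring, so the measured steps bear on it only loosely; they show amide-side changes moving the read-out by small amounts in either direction. Compound 4 is therefore expected to show no step beyond the scatter, a number 0.3 percentage points higher from compound 1 to compound 4 (within the scatter), with an estimate of 30% in a range from 15% to 45%.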

Compound 4, a percentage reported as inhibition, in the whole organism at one dose (the size of the read-out at that dose, not a potency): 32%
The estimate for compound 4 lay 2 percentage points below the measured number; the range from low to high includes it.
By their numbers in this assay, from the lowest: compounds 3, 1, 4 and 2 (each within the scatter of the next, the first and the last beyond it).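

For the compounds shown here, replacing methylamino with piperidin-1-yl on a carbonyl carbon removes the amide hydrogen and closes the nitrogen into a ring, a change the earlier compounds did not include. In this assay all three steps to compound 4 stay within the scatter: a number 2.3 percentage points higher from compound 1 to compound 4 (within the scatter), a number 7 percentage points higher from compound 3 to compound 4 (within the scatter) and a number 7.1 percentage points lower from compound 2 to compound 4 (within the scatter). Nothing available explains this result. Whether pyrrolidin-1-yl, morpholin-4-yl or a carboxylic acid at this carbonyl carbon would also stay within the scatter of these compounds remains open.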